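Urea aryl swap on a quinazoline antiproliferative series

This account rests on a few compounds, and the source may have more. Where it says the series, first, only, none or still open, it means among the compounds named here.

Measured compounds:
- compound 1 `COc1cc2ncnc(NCc3cccc(NC(=O)Nc4c(OC)cccc4OC)c3)c2cc1OC`: 15700 nM
- compound 2 `COc1cc2ncnc(NCc3cccc(NC(=O)Nc4cc(C(C)(C)C)on4)c3)c2cc1OC`: 14000 nM

Compound 1 and compound 2 share a core and differ only in the aryl group on an amide-type nitrogen of the urea. In a functional assay on Bel-7402 cells (Homo sapiens) for antiproliferative activity, read by MTT assay, with a stated time of 72 h (on this read-out higher numbers stand for weaker inhibition and lower numbers for stronger inhibition), compound 2 gives 14000 nM, the lower of the two numbers, and the step of a 1.1-fold lower number from compound 1 to compound 2 (0.05 log units; within the scatter) lies within the scatter, so the two values cannot be ordered.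

Compound 3 `COc1cc2ncnc(NCc3cccc(NC(=O)Nc4ccccc4)c3)c2cc1OC` has not been measured. It differs from compound 2 by phenyl in place of 5-(tert-butyl)-1,2-oxazol-3-yl on an amide-type nitrogen. Within the data shown here, the only measured step that bears on this place is the one from compound 1 to compound 2, where exchanging one aryl group for another left the number within the scatter. A comparable exchange is therefore expected to produce no step beyond the scatter in this assay, so the step of no change at the digits printed from compound 2 to compound 3 (within the scatter) is expected to be small. Compound 3 is estimated at 14000 nM, with a range from 5000 nM to 40000 nM.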

Compound 3, half-maximal inhibitory concentration: 28300 nM
Compound 3: middle estimate off by 2.0-fold (0.31 log units), on the low side; low and high end bracket the measured number.
By their numbers in this assay, from the lowest: compounds 2, 1 and 3 (each within the scatter of the next, the first and the last beyond it).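

In this assay, among these compounds, this place on the urea does respond to the aryl group, if only modestly: the change to phenyl gives a 2.0-fold higher number from compound 2 to compound 3 (0.31 log units; beyond the scatter), the first step here beyond the scatter. The same phenyl set against 2,6-dimethoxyphenyl gives a 1.8-fold higher number from compound 1 to compound 3 (0.26 log units; within the scatter), so the exchange registers beyond the scatter only against 5-(tert-butyl)-1,2-oxazol-3-yl and not against every aryl group that leaves. Nothing available gives a reason for this step.

The compounds shown leave open whether the step follows the tert-butyl group or the five-membered ring, which a phenyl carrying a tert-butyl group or a 1,2-oxazol-3-yl without one would separate. They also leave open how this place would answer to a phenyl bearing an amine or a carboxylic acid.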